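Replacing the sulfonamide with a hydroxypropylpiperazine

The compounds below may be only part of what the source reports. "The series", "measured", "known", "first", "only" and "open" are said of these compounds alone.

Notes on compound 1 `COc1ccc(Nc2ncc3ccc(-c4ccccc4OC)n3n2)cc1` and compound 2 `COc1ccccc1-c1ccc2cnc(Nc3ccc(S(=O)(=O)N(C)C)cc3)nn12`, which share one core and differ at a single position. In an in vitro ADME assay on microsomes from liver (Canis lupus familiaris, strain beagle) for metabolic stability, using NADPH, with a stated time of 10 min, tested at 0.5 uM (on this read-out lower numbers stand for a shorter-lived compound and higher numbers for a longer-lived compound), compound 1 gives 0.0833 h, and compound 2 gives 0.117 h. Going by the values given here, the one measured step, a 1.4-fold higher number from compound 1 to compound 2 (0.15 log units; within the scatter), follows dimethylsulfamoyl in place of methoxy on an aromatic carbon. Compound 2 thus stands alongside compound 1, the two numbers separated by no more than the scatter.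

Compound 3 `COc1ccccc1-c1ccc2cnc(Nc3ccc(N4CCN(C[C@H](C)O)CC4)cc3)nn12` is the next member. It differs from compound 2 by 4-(2-hydroxypropyl)piperazin-1-yl in place of dimethylsulfamoyl on an aromatic carbon. Among the compounds with values here, no measured step covers a group of this kind. Within the data shown here, the only step that bears on the question, a 1.4-fold higher number from compound 1 to compound 2 (0.15 log units; within the scatter), shows that exchanging methoxy for dimethylsulfamoyl left this assay within the scatter, and both measured values lie close together. On that basis no step beyond the scatter is expected from compound 2 to compound 3, though the lack of any comparable change leaves the direction open. Compound 3 is therefore estimated at 0.1 h in this assay, with a range from 0.04 h to 0.3 h. This corresponds to an expected step of a 1.2-fold lower number from compound 2 to compound 3 (0.07 log units; within the scatter).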

Compound 3, half-life: > 0.666 h
Compound 3 was reported as a limit; the forecaster's own chance of this, stated with the estimate: 15%; at least 6.6-fold (0.82 log units) between middle value and limit.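

The position on the aromatic carbon, where the earlier exchange of groups had stayed within the scatter, now shows that the read-out can respond to the group placed there: 4-(2-hydroxypropyl)piperazin-1-yl in place of dimethylsulfamoyl gives an at least 5.6-fold higher number from compound 2 to compound 3 (0.75 log units; beyond the scatter), and in place of methoxy it gives an at least 7.9-fold higher number from compound 1 to compound 3 (0.90 log units; beyond the scatter). For compound 3 the read-out in this assay is a limit and not a number: the limit of > 0.666 h in this assay, at which 1 of the 3 values shown sits. Both steps are therefore lower bounds on the size of the change, yet each already lies beyond the scatter, which neither the methoxy nor the dimethylsulfamoyl compound had suggested for this position.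

The entering group brings a six-membered non-aromatic ring with 2 hetero atoms, a hydroxypropyl chain and a defined stereocentre all at once, so the compounds shown cannot assign the step to any one of these parts. On these data alone, a 4-methylpiperazin-1-yl or morpholine group at this place, or the opposite stereocentre on the hydroxypropyl chain, would be needed to separate them, and how far compound 3 lies past its limit also remains open.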